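The source may hold more compounds than are shown below. What is called first, only, known or untested is meant among the compounds shown, and "the series" means these compounds.

Three measured compounds share one core. Compound 1 `CN(C)CN1C(=O)C(=O)c2c(Br)cccc21` gives 57600 nM in a functional assay on MCF7 cells (Homo sapiens) for cytotoxicity, read by sulforhodamine B assay, with a stated time of 48 h (a higher number here means a weaker inhibitor of growth, a lower number a stronger inhibitor of growth), and compound 3 `CN(C)CN1C(=O)C(=O)c2c(Cl)cccc21` gives 87800 nM in this assay. Compound 2 `CCN(CC)CN1C(=O)C(=O)c2c(Cl)cccc21` gives 34100 nM in this assay, the lowest of the three numbers. Compound 1 lies within the scatter of compound 2, whereas the modest step of a 2.6-fold higher number from compound 2 to compound 3 (0.41 log units; beyond the scatter) lies beyond it. The unmeasured compound 4 `CCN(CC)CN1C(=O)C(=O)c2c(Br)cccc21` arises from compound 2 by bromo in place of chloro on an aromatic carbon. Within the data shown here, the one measured step of this kind runs the other way, a 1.5-fold higher number from compound 1 to compound 3 (0.18 log units; within the scatter), and stays within the scatter. Compound 4 is therefore expected to show only a small shift in this assay, a 1.5-fold lower number from compound 2 to compound 4 (0.17 log units; within the scatter), if anything toward a lower number. The estimate for compound 4 is 23000 nM, with a range from 12000 nM to 50000 nM.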

Compound 4, concentration for 50% growth inhibition: 20200 nM
Beside the measured number, compound 4's estimate is 1.1-fold (0.06 log units) above it; measured number inside the range.
By their numbers in this assay, from the lowest: compounds 4, 2, 1 and 3 (each within the scatter of the next, the first and the last beyond it).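

In this assay, bromo in place of chloro on the aromatic carbon also stays within the scatter when diethylamino is present, a 1.7-fold lower number from compound 2 to compound 4 (0.23 log units; within the scatter). The halogen step therefore reads alike with both amines: the same change on two cores in this assay, a 1.5-fold higher number (0.18 log units; within the scatter) from compound 1 to compound 3 and a 1.7-fold higher number (0.23 log units; within the scatter) from compound 4 to compound 2, 1.1-fold (0.04 log units) apart, within the scatter of two such steps. Diethylamino in place of dimethylamino now also goes beyond the scatter with bromo on the ring, a 2.9-fold lower number from compound 1 to compound 4 (0.46 log units; beyond the scatter), and matches its step with chloro: the same change on two cores in this assay, a 2.6-fold higher number (0.41 log units; beyond the scatter) from compound 2 to compound 3 and a 2.9-fold higher number (0.46 log units; beyond the scatter) from compound 4 to compound 1, 1.1-fold (0.04 log units) apart, within the scatter of two such steps. The compounds shown leave open how a longer chain on the amine would read, and what fluoro or methyl would give on this aromatic carbon.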